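Alkoxy chain length on the acid-bearing ring: compound 3 to compound 4

The compounds below may be only part of what the source reports. "The series", "measured", "known", "first", "only" and "open" are said of these compounds alone.

Measured compounds:
Compound 1, `CC(C)c1onc(-c2c(Cl)cccc2Cl)c1COc1ccc(-c2ccc3cc(C(=O)O)cnc3c2)cc1`; in a functional assay on CV-1 cells for agonist activity at Bile acid receptor (Homo sapiens), read by a luciferase reporter (a higher number here means that more compound is needed for the effect, a lower number that less compound is needed), compound 1 gives 260 nM.
Compound 2, `CCc1cc(C(=O)O)nc2ccc(-c3ccc(OCc4c(-c5c(Cl)cccc5Cl)noc4C(C)C)cc3)cc12`; compound 2 gives 32 nM.
Compound 3, `CCOc1cc(C(=O)O)nc2ccc(-c3ccc(OCc4c(-c5c(Cl)cccc5Cl)noc4C(C)C)cc3)cc12`; compound 3 gives 14 nM.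

Compound 3 holds the lowest number of the three. Going by the values given here, its nearest neighbour is compound 2, by the step of a 2.3-fold lower number from compound 2 to compound 3 (0.36 log units; beyond the scatter), which is the only single-point step among the measured compounds. Compound 1, carrying no substituent at that position of the shared core, sits furthest away: compound 1 at 260 nM against compound 3 at 14 nM.

Compound 4, `CCCOc1cc(C(=O)O)nc2ccc(-c3ccc(OCc4c(-c5c(Cl)cccc5Cl)noc4C(C)C)cc3)cc12`, differs from compound 3 by methyl in place of hydrogen on a saturated chain carbon, two bonds along the chain from an oxygen on an aromatic ring. Among the compounds with values here, the one measured step, a 2.3-fold lower number from compound 2 to compound 3 (0.36 log units; beyond the scatter), concerns exchanging ethyl for ethoxy, not extending a chain by one carbon, so nothing measured here tests the chain length itself. The modest size of that step and the absence of a direct precedent leave little ground for expecting a large shift in either direction.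

The step from compound 3 to compound 4 is therefore expected to be a 1.2-fold lower number from compound 3 to compound 4 (0.07 log units; within the scatter), within the scatter. In this assay compound 4 is estimated at 12 nM, with a range of 5 nM to 30 nM.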

Compound 4, half-maximal effective concentration: 22 nM
Beside the measured number, compound 4's estimate is 1.8-fold (0.26 log units) below it, within the range that was stated.
By their numbers in this assay, from the lowest: compounds 3, 4 and 2 (each within the scatter of the next, the first and the last beyond it); then compound 1.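

In this assay, going by these compounds alone, a 1.6-fold higher number from compound 3 to compound 4 (0.20 log units; within the scatter) gives the first direct reading of chain length at this position: ethoxy and propoxy, which differ by methyl in place of hydrogen on a saturated chain carbon, two bonds along the chain from an oxygen on an aromatic ring, cannot be told apart. Against ethyl, a 1.5-fold lower number from compound 2 to compound 4 (0.16 log units; within the scatter) also stays within the scatter, whereas a 2.3-fold lower number from compound 2 to compound 3 (0.36 log units; beyond the scatter) lies beyond it, so the clear separation from ethyl seen with ethoxy is not repeated with propoxy, and the series gives no firm ground for saying that alkoxy groups in general separate from ethyl. No accompanying measurement bears on this result, so the values themselves offer no explanation of it.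

Still open, going by these compounds, is whether butoxy or a longer chain, or a branched isopropoxy, would keep the number in the range of compound 3 and compound 4 or move it clearly away. Also open, on these data alone, is how methoxy or an amine on the same aromatic carbon would read in this assay, which would show whether the ethyl-to-ethoxy step reflects more than a single case.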